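From Phenyl Triazole to Acetoxy on a Saturated Ring

This account rests on a few compounds, and the source may have more. Where it says the series, first, only, none or still open, it means among the compounds named here.

In an ADME assay on microsomes from liver (Homo sapiens) for metabolic stability, read by LC-MS, with NADPH named in the record, with a stated time of 60 min, tested at 1 uM, in the absence of a further agent (a lower number here means that less of the compound is left, a higher number that more of the compound is left), compound 1 (`COc1ccc(-c2c(C)nc3c(N4CC[C@@H](SC(C)=O)C4)cc(C)nn23)cc1OC`) gives > 95% as a limit of the assay, not a number. Compound 2 (`COc1ccc(-c2c(C)nc3c(N4CC[C@@H](n5cc(-c6ccccc6)nn5)C4)cc(C)nn23)cc1OC`) has no figure to place on that scale: in this assay compound 2 is recorded only in the word "unstable" (no number reported) and nothing more exact. Compound 3 (`COc1ccc(-c2c(C)nc3c(N4CC[C@@H](OC(C)=O)C4)cc(C)nn23)cc1OC`) has not yet been measured. The change acetoxy in place of 4-phenyl-1H-1,2,3-triazol-1-yl on a saturated ring carbon puts acetoxy in place of 4-phenyl-1H-1,2,3-triazol-1-yl on a saturated ring carbon. A large step towards more compound left is expected, although its size cannot be fixed without a figure for compound 2. This expectation leans on compound 1, which also lacks the 4-phenyl-1H-1,2,3-triazol-1-yl group and is recorded at > 95% as a limit. In this assay the expected value for compound 3 is 80% (estimated range 45% to 100%).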

Compound 3, percent of the compound remaining: > 95%
Compound 3: only a limit was reported (the forecaster's own chance of this, stated with the estimate: 35%); middle value at least 15 percentage points from the limit.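

No step can be read from compound 1 to compound 3 or from compound 2 to compound 3, because compound 2 has only a word and the other two compounds stop at the same limit: the limit of > 95% in this assay, at which 2 of the 3 values shown sit.

The compounds shown leave open whether acetoxy and acetylsulfanyl differ at all in this assay.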